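Swapping a piperidine on an adenosine receptor antagonist core

A few compounds are considered here, and "the series" means these few. Any claim that something is new, unique, unknown or untested is made for them only; others in the source may bear on it.

Compound 1, `C[C@@H]1CCC[C@H](C)N1Cc1cc2c(N)nc(-c3ccc(C(F)F)o3)nc2s1`: 730 nM
Compound 2, `Nc1nc(-c2ccc(C(F)F)o2)nc2sc(CN3CCC(F)CC3)cc12`: 1670 nM
Compound 3, `C[C@@H]1CCC[C@H](C)N1Cc1cc2c(N)nc(-c3cccc(C#N)c3)nc2s1`: 460 nM

These three compounds were tested in an assay on CHO-K1 cells for antagonist activity at adenosine receptor A1 (Homo sapiens), read by a beta-galactosidase reporter, with stated times of 15 min and 6 h; on this read-out lower numbers stand for stronger inhibition and higher numbers for weaker inhibition. Compound 1 and compound 2 share one core and differ only in the amine attached through a saturated chain carbon to that core: 4-fluoropiperidin-1-yl in place of 2,6-dimethylpiperidin-1-yl on a saturated chain carbon bound to an aromatic carbon. This change gave a 2.3-fold higher number from compound 1 to compound 2 (0.36 log units; beyond the scatter). Compound 1 and compound 3 keep the same amine on the chain but carry different groups on the core itself: 3-cyanophenyl in place of 5-(difluoromethyl)furan-2-yl on an aromatic carbon. Here the change gave a 1.6-fold lower number from compound 1 to compound 3 (0.20 log units; within the scatter), so compound 1 and compound 3 cannot be told apart on this read-out.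

Compound 4, `N#Cc1cccc(-c2nc(N)c3cc(CN4CCC(F)CC4)sc3n2)c1`, has not yet been measured. It stands to compound 3 exactly as compound 2 stands to compound 1: 4-fluoropiperidin-1-yl in place of 2,6-dimethylpiperidin-1-yl on a saturated chain carbon bound to an aromatic carbon. The place is the same in both pairs, a saturated chain carbon bound to an aromatic carbon, so this is the same change, made on a core that differs only in the way described for compound 1 and compound 3. If the change acts the same way on the core of compound 3, the expected step is a 2.3-fold higher number from compound 3 to compound 4 (0.36 log units; beyond the scatter). Among the measured compounds shown here, that expectation rests on compound 1 and compound 2 alone, through a 2.3-fold higher number from compound 1 to compound 2 (0.36 log units; beyond the scatter), and no second pair is available to check it. Compound 4 is therefore estimated at 1060 nM, with a range from 500 nM to 2300 nM.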

Compound 4, inhibition constant: 2950 nM
For compound 4 the middle estimate is 2.8-fold (0.44 log units) below the measured one; the measured number lies above the stated range.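

In this assay, the swap to 4-fluoropiperidin-1-yl gave a higher number on both cores, but with a 6.4-fold higher number from compound 3 to compound 4 (0.81 log units; beyond the scatter) the direction carried over from the first pair and the size did not: the same change on two cores in this assay, a 2.3-fold higher number (0.36 log units; beyond the scatter) from compound 1 to compound 2 and a 6.4-fold higher number (0.81 log units; beyond the scatter) from compound 3 to compound 4, 2.8-fold (0.45 log units) apart, beyond the scatter of two such steps. Seen from the other side, with 4-fluoropiperidin-1-yl held fixed, the change of core group gives a 1.8-fold higher number from compound 2 to compound 4 (0.25 log units; within the scatter), so compound 2 and compound 4 cannot be told apart, just as compound 1 and compound 3 cannot, and yet the two steps still stand apart: the same change on two cores in this assay, a 1.6-fold lower number (0.20 log units; within the scatter) from compound 1 to compound 3 and a 1.8-fold higher number (0.25 log units; within the scatter) from compound 2 to compound 4, 2.8-fold (0.45 log units) apart, beyond the scatter of two such steps. This shows that, in this small set, the effect of the amine swap depends on the group carried by the core and cannot simply be added to it, but two cores cannot show why this happens or predict the size of the step on a third core.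

From the compounds shown here alone, it remains open whether the step comes from losing the two methyl groups or from gaining the fluorine, a question that plain piperidine on the same chain carbon could help to settle. A third core group, such as phenyl or pyridin-3-yl, could show whether the size of the step follows any trend across cores.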